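A few compounds are considered here, and "the series" means these few. Any claim that something is new, unique, unknown or untested is made for them only; others in the source may bear on it.

- Compound 1 `CC(C)n1ncc2c(C(=O)Nc3c(F)cc(F)cc3F)cc(-c3cccs3)nc21`: > 200000 nM, a limit of the assay
- Compound 2 `CC(C)n1ncc2c(C(=O)Nc3ccccc3F)cc(-c3cccs3)nc21`: 50000 nM

Among the measured compounds shown here, in an ADME assay on LLC-MK2 cells (Macaca mulatta) for cytotoxicity, read by spectrophotometry and crystal violet staining, with a stated time of 4 days (on this read-out higher numbers stand for lower toxicity in this test and lower numbers for higher toxicity in this test), compound 2 gives 50000 nM, the only actual number so far. Compound 3 `CC(C)n1ncc2c(C(=O)Nc3cccc(S(N)(=O)=O)c3)cc(-c3cccs3)nc21` carries 3-sulfamoylphenyl in place of 2-fluorophenyl on an amide-type nitrogen. One measured step changed the group at this place: an at least 4.0-fold lower number from compound 1 to compound 2 (0.60 log units; beyond the scatter), with 2-fluorophenyl in place of 2,4,6-trifluorophenyl. That step shows that this place can move the number and leaves compound 2 at the lower end, so a modest rise is expected. The expected change is a 1.8-fold higher number from compound 2 to compound 3 (0.26 log units; within the scatter). For compound 3 the estimate is 90000 nM, with an expected range from 30000 nM to 200000 nM.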

Compound 3, half-maximal cytotoxic concentration: 25000 nM
Compound 3: middle estimate off by 3.6-fold (0.56 log units), on the high side, and the stated range ends above it.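

In this assay, a larger group with a hydrogen-bond donor, 3-sulfamoylphenyl, leaves the number indistinguishable from that of 2-fluorophenyl: a 2.0-fold lower number from compound 2 to compound 3 (0.30 log units; within the scatter). Against 2,4,6-trifluorophenyl, the same group gives an at least 8.0-fold lower number from compound 1 to compound 3 (0.90 log units; beyond the scatter), so compound 1 now stands apart from both compound 2 and compound 3. The true size of that gap stays open-ended, because of this: the limit of > 200000 nM in this assay, at which 1 of the 3 values shown sits.

Still open, from the compounds shown here alone, is whether an amine or a carboxylic acid on the phenyl ring would stay level with compound 2 and compound 3. Plain unsubstituted phenyl would also show whether the fluorines matter.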